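The source may report more compounds than this note shows. Statements on the series, on what has been measured and on what is new or still open speak of the compounds shown alone.

Measured compounds:
- compound 1 `CC(C)OC(=O)N1CCC(COc2ccc(N3CCN(C(=O)N(C)C)CC3)nc2)CC1`: in a functional assay on CHO-K1 cells for agonist activity at Glucose-dependent insulinotropic receptor (Homo sapiens), read by a luciferase reporter, with a stated time of 5 h (a higher number here means that more compound is needed for the effect, a lower number that less compound is needed), compound 1 gives > 10000 nM, a limit of the assay, not a number.
- compound 2 `CC(C)NC(=O)CN1CCN(c2ccc(OCC3CCN(C(=O)OC(C)C)CC3)cn2)CC1`: compound 2 gives > 10000 nM, again a limit.
- compound 3 `CCS(=O)(=O)N1CCN(c2ccc(OCC3CCN(C(=O)OC(C)C)CC3)cn2)CC1`: compound 3 gives 1300 nM.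

For the measured compounds named here, compound 3 carries the only number in the set; the other two values sit at the limit (the limit of > 10000 nM in this assay, at which 2 of the 3 values shown sit). The steps onto compound 3, an at least 7.6-fold lower number from compound 1 to compound 3 (0.88 log units; beyond the scatter) and an at least 7.6-fold lower number from compound 2 to compound 3 (0.88 log units; beyond the scatter), both read as at least modest and beyond the scatter, so the group on the ring amine nitrogen is where the series has moved so far. The step from compound 1 to compound 2, a step that the two limits leave unreadable from compound 1 to compound 2, cannot be read.

Compound 4 `COCCS(=O)(=O)N1CCN(c2ccc(OCC3CCN(C(=O)OC(C)C)CC3)cn2)CC1` differs from compound 3 by methoxy in place of hydrogen on a saturated chain carbon, two bonds along the chain from a sulfonyl sulfur. Going by the values given here, none of the measured steps touches a chain carbon beyond the sulfonyl sulfur, so nothing here sets a direction for this change. The ethylsulfonyl is retained, and the expectation is that compound 4 stays near compound 3, with a step of a 1.2-fold higher number from compound 3 to compound 4 (0.06 log units; within the scatter) inside the scatter in this assay. Compound 4 is estimated at 1500 nM, within 500 nM to 5000 nM.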

Compound 4, half-maximal effective concentration: 300 nM
The estimate for compound 4 lay 5.0-fold (0.70 log units) above the measured number; measured number outside the range, below it.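

In this assay, the chain beyond the sulfonyl sulfur proves to be a place that responds: methoxy in place of hydrogen on a saturated chain carbon, two bonds along the chain from a sulfonyl sulfur, gives a 4.3-fold lower number from compound 3 to compound 4 (0.64 log units; beyond the scatter). For the compounds shown here, this is the first readable step that keeps the sulfonyl and changes only its chain, and ethyl to 2-methoxyethyl extends the movement already seen on going to a sulfonyl on the ring amine nitrogen. The whole-group exchanges now read as an at least 33-fold lower number from compound 2 to compound 4 (1.52 log units; beyond the scatter) and an at least 33-fold lower number from compound 1 to compound 4 (1.52 log units; beyond the scatter), and both start from a limit of the assay, not a number: the limit of > 10000 nM in this assay, at which 2 of the 4 values shown sit.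

The compounds shown leave open whether the oxygen or the greater chain length carries the step. A plain butyl chain on the sulfonyl would separate the two, and a 2-hydroxyethyl or 2-aminoethyl chain would test whether the ether oxygen can be replaced.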